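Pyrazole regioisomers on an imidazoline aniline core

The compounds below may be only part of what the source reports. "The series", "measured", "known", "first", "only" and "open" are said of these compounds alone.

Measured compounds:
- compound 1, `Cn1cc(-c2ccccc2NCC2=NCCN2)cn1`: 0%
- compound 2, `CCn1nccc1-c1ccccc1NCC1=NCCN1`: 0%

In a functional assay with Alpha-1D adrenergic receptor (Homo sapiens) as the target, read by calcium flux (on this read-out lower numbers stand for smaller maximal responses and higher numbers for larger maximal responses), compound 1 gives 0%. In this assay compound 2 gives 0%. Compound 1 stands level with compound 2 at the digits reported; the two values lie within the scatter of each other, so no order between them can be stated. Both carry the same imidazolinylmethylaminophenyl core and differ only in the pyrazole and its alkyl group, and both sit at the floor of the read-out.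

Compound 3, `Cn1nccc1-c1ccccc1NCC1=NCCN1`, is not yet measured. It differs from compound 1 as follows: 1-methyl-1H-pyrazol-5-yl in place of 1-methyl-1H-pyrazol-4-yl on an aromatic carbon. The change moves the attachment point of the same ring; compound 2 already carries the pyrazol-5-yl attachment and shows no response. Since compound 1 and compound 2 show no measurable response in this assay, no step beyond the scatter is expected from compound 1 to compound 3, and the expected step is no change at the digits printed from compound 1 to compound 3 (within the scatter). Compound 3 is therefore estimated at 0%, with a range from 0% to 10%.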

Compound 3, largest response reached (reported as maximal response), in percent of the reference or control that the assay uses: 0%
Compound 3: middle estimate and measured number agree at the digits printed; the measured number falls inside the stated range.
By their numbers in this assay, from the lowest: compounds 1, 2 and 3 (each within the scatter of the next).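

In this assay, 1-methyl-1H-pyrazol-5-yl in place of 1-methyl-1H-pyrazol-4-yl on an aromatic carbon gives no change at the digits printed from compound 1 to compound 3 (within the scatter) and thus shows that, with the methyl group held constant, changing the attachment point alone does not lift the response off the floor of the read-out. Hydrogen in place of methyl on the saturated chain carbon bound to the aromatic nitrogen gives no change at the digits printed from compound 2 to compound 3 (within the scatter) and thus separates the alkyl change from the attachment change, with neither producing a detectable response. No supporting data bear on this result.

Going by these compounds, with all three compounds at the floor, the effect of either change on a measurable response remains unknown. On these data alone, whether a primary amine on the pyrazole or a longer chain on its nitrogen would produce any response also remains open.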